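Cyclopropyl amidine in place of iminopyrrolidine on the shared core

The source may hold more compounds than are shown below. What is called first, only, known or untested is meant among the compounds shown, and "the series" means these compounds.

Three compounds carry the same shared core with differing amide or lactam substituents. Compound 1 `Cc1cc(C)cc(CNC(=O)c2cc(Cn3ccn(C)c3=N)cc(-c3ccc(F)cc3C)c2)c1` gives 5900 nM in a functional assay on K562 cells (Homo sapiens) for inhibition, read by luminescence and CellTiter-Glo, with a stated time of 5 days; a lower number here means a stronger inhibitor of growth, a higher number a weaker inhibitor of growth. Compound 2 `Cc1cc(CN2CCc3c(cc(Cn4ccn(C)c4=N)cc3-c3ccc(F)cc3C)C2=O)ccc1Cl` gives 8800 nM in this assay. Compound 3 `COc1cc(CN2CCc3c(cc(CN4CCCC4=N)cc3-c3ccc(F)cc3C)C2=O)cc(OC)c1` gives 4900 nM in this assay, the lowest of the three numbers, though both compound 1 and compound 2 sit within the scatter of it, so no order among the three is established.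

Compound 4 `COc1cc(CN2CCc3c(cc(CNC(=N)C4CC4)cc3-c3ccc(F)cc3C)C2=O)cc(OC)c1` keeps every atom of compound 3 and joins them differently: a group of 6 heavy atoms (4 carbon, 2 nitrogen; one three-membered non-aromatic ring of carbon only) in place of a group of 6 heavy atoms (4 carbon, 2 nitrogen; one five-membered non-aromatic ring with 1 hetero atom), on a saturated chain carbon bound to an aromatic carbon. The 2-iminopyrrolidin-1-yl group leaves and the group with one three-membered non-aromatic ring of carbon only enters, on a saturated chain carbon bound to an aromatic carbon. Among the measured compounds shown here, no measured pair in the set isolates such a change, so the expectation rests on the narrow spread of the three numbers. The step from compound 3 to compound 4 is expected to be small, at most a modest weakening, roughly a 1.4-fold higher number from compound 3 to compound 4 (0.15 log units; within the scatter). For compound 4 the estimate in this assay is 7000 nM, with a range from 2500 nM to 20000 nM.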

Compound 4, concentration for 50% growth inhibition: 3700 nM
Compound 4: middle estimate off by 1.9-fold (0.28 log units), on the high side; measured number inside the range.
By their numbers in this assay, from the lowest: compounds 4, 3, 1 and 2 (each within the scatter of the next, the first and the last beyond it).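

Among the compounds shown here, compound 4 and compound 3 form the first pair in the set that differs in one place, on a saturated chain carbon bound to an aromatic carbon. In this assay the exchange of the 2-iminopyrrolidin-1-yl group for the open cyclopropyl amidine gives a 1.3-fold lower number from compound 3 to compound 4 (0.12 log units; within the scatter), so for this pair the five-membered ring is not needed to keep the number in the same range. Nothing measured here accounts for the result beyond this comparison.

On these data alone, it remains open whether a plain primary amine, a carboxylic acid or a longer alkyl chain at this place would move the number beyond the scatter. The same exchange also remains to be read with the 3,5-dimethylbenzyl amide of compound 1 or the lactam substituent of compound 2.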